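Chlorine to Methyl on the Aryl Amide Nitrogen

The compounds below may be only part of what the source reports. "The series", "measured", "known", "first", "only" and "open" are said of these compounds alone.

Compound 1, `COc1ccccc1NC(=S)N/N=C/c1ccc2ccccc2n1`: 91700 nM in a functional assay on HL-60 cells (Homo sapiens) for antiproliferative activity, read by sulforhodamine B assay, with a stated time of 72 h; on this read-out lower numbers stand for stronger inhibition and higher numbers for weaker inhibition
Compound 2, `COc1cccc(NC(=S)N/N=C/c2ccc3ccccc3n2)c1`: 71200 nM
Compound 3, `S=C(N/N=C/c1ccc2ccccc2n1)Nc1ccc(Cl)cc1`: a limit of the assay, > 100000 nM

Three compounds share a core and differ only in the aryl group on the amide-type nitrogen. Compound 3 sits at the limit of > 100000 nM in this assay, at which 1 of the 3 values shown sits, so for it only a limit is known and no number. The three measured steps all stay small: a 1.3-fold lower number from compound 1 to compound 2 (0.11 log units; within the scatter), an at least 1.0-fold higher number from compound 1 to compound 3 (0.03 log units; that floor lies within the scatter) and an at least 1.4-fold higher number from compound 2 to compound 3 (0.14 log units; that floor lies within the scatter). Within this set the aryl substituent, whether a methoxy group in two positions or a chlorine, leaves the read-out where it is, within the scatter.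

Compound 4, `Cc1ccccc1NC(=S)N/N=C/c1ccc2ccccc2n1`, brings the next variation: 2-methylphenyl in place of 4-chlorophenyl on an amide-type nitrogen. Going by the values given here, the steps that bear on it, from compound 1 and compound 2 to compound 3, were both within the scatter, so no step beyond the scatter is expected in this assay in either direction; the change from compound 3 to compound 4 is estimated as a number no higher from compound 3 to compound 4 (the limit leaves the size open). Compound 4 is therefore expected to give about 100000 nM, with a range from 50000 nM to 200000 nM, and a fair chance that again only a limit is reported.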

Compound 4, half-maximal inhibitory concentration: 73200 nM
Beside the measured number, compound 4's estimate is 1.4-fold (0.14 log units) above it; the range from low to high includes it.
By their numbers in this assay, from the lowest: compounds 2, 4 and 1 (each within the scatter of the next). At a limit, above all of these: compound 3.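

Going by these compounds alone, compound 4 adds the first single-group comparison that leaves the aryl ring and its position unchanged: methyl in place of methoxy on an aromatic carbon gives a 1.3-fold lower number from compound 1 to compound 4 (0.10 log units; within the scatter). Set against the other aryl groups on the amide-type nitrogen in this assay, 2-methylphenyl gives a 1.0-fold higher number from compound 2 to compound 4 (0.01 log units; within the scatter) and an at least 1.3-fold lower number from compound 3 to compound 4 (0.13 log units; that floor lies within the scatter), so an aryl group made of carbon alone also leaves the read-out within the scatter of the methoxy compounds. The last of these steps is only a floor, and its true size stays unknown, because the figure for compound 3 is a limit and not a number: the limit of > 100000 nM in this assay, at which 1 of the 4 values shown sits.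

The compounds shown leave open whether any change on this nitrogen can move the read-out beyond the scatter, since they cover only methoxy, chloro and methyl groups on a phenyl ring. An amine or a carboxylic acid on that ring, a longer chain in place of the methyl, or a change to the shared core itself might tell more, and none of these can be judged from the values at hand.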